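Methyl in place of hydrogen on compound 2

The source may report more compounds than this note shows. Statements on the series, on what has been measured and on what is new or still open speak of the compounds shown alone.

Measured so far, with a functional assay on HL-60 cells (Homo sapiens) (a higher number here means that more compound is needed for the effect, a lower number that less compound is needed), as the read-out:
- compound 1 `COc1cc(/C=C/c2cc(OC)c(O)c(OC)c2)cc(OC)c1` gives 79000 nM as measured
- compound 2 `COc1cc(OC)cc(-c2ccc(-c3ccc(O)cc3)cc2)c1` gives 30000 nM as measured

Of these two numbers, compound 2 holds the lower one. Compound 2 at 30000 nM stands under compound 1 at 79000 nM by a gap beyond the usual scatter, so less of compound 2 is needed for the effect.

The next compound to be read is compound 3 (`COc1ccc(-c2ccc(-c3cc(OC)cc(OC)c3)cc2)cc1`), which departs from compound 2 at a single place: methyl in place of hydrogen on an oxygen on an aromatic ring (methyl in place of hydrogen on an oxygen on an aromatic ring, or 4-hydroxyphenyl to 4-methoxyphenyl).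

Among the measured compounds shown here, no measured pair differs in one place only, so this change has no direct precedent here. A modest move towards a higher number is expected, and it may stay within the scatter. The expected size is a 1.7-fold higher number from compound 2 to compound 3 (0.22 log units; within the scatter) on this estimate. In this assay the estimate for compound 3 is 50000 nM, expected to fall from 15000 nM to 150000 nM when measured.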

Compound 3, concentration for half-maximal activity: > 100000 nM
Compound 3 gave a limit, no number; the forecaster's own chance of this, stated with the estimate: 25%; middle value at least 2.0-fold (0.30 log units) away from the limit.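

In this assay, the series now has its first comparison at a single place: methyl in place of hydrogen on the oxygen of the 4-hydroxyphenyl gives an at least 3.3-fold higher number from compound 2 to compound 3 (0.52 log units; beyond the scatter). This shows that the read-out responds to this position and that, for this pair, the 4-methoxyphenyl needs more compound than the 4-hydroxyphenyl, a direction that compounds 1 and 2 alone could not show. Compound 3 gives a limit and not a number: the limit of > 100000 nM in this assay, at which 1 of the 3 values shown sits.

The direction of the step is therefore settled, but its full size is not, and the pair cannot separate the hydrogen on this oxygen from the added methyl as the source of the change. Among the compounds shown here, an amine or a carboxylic acid in place of the hydroxy, or an ethyl group in place of the methyl on the oxygen, would show how narrow the requirement at this position is, while the methoxy groups shared by compound 2 and compound 3 still have no step of their own.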